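This account rests on a few compounds, and the source may have more. Where it says the series, first, only, none or still open, it means among the compounds named here.

Compound 1 `COc1cccc(/C=C2\CCC/C(=C\c3ccc(Cl)cc3)C2=O)c1OC`: > 20000 nM
Compound 2 `COc1ccc(/C=C2\CCC/C(=C\c3cccc(OC)c3OC)C2=O)cc1`: > 20000 nM
Compound 3 `COc1cccc(/C=C2\CCC/C(=C\c3ccc(O)cc3)C2=O)c1OC`: > 20000 nM

All three compounds were tested in a functional assay on A549 cells (Homo sapiens) for cytotoxicity, read by MTT assay, with a stated time of 72 h (a higher number here means a weaker inhibitor, a lower number a stronger inhibitor), and each entry is a limit of the assay rather than a number. In this assay compound 3 gives > 20000 nM, which is such a limit. The whole set stands at the limit of > 20000 nM in this assay, at which 3 of the 3 values shown sit, so compound 3 offers no measured potency to build on.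

Compound 4 `COc1cccc(/C=C2\CCC/C(=C\c3ccc(O)c(O)c3)C2=O)c1OC` differs from compound 3 in one place: hydroxy in place of hydrogen on an aromatic carbon. In words, a hydroxy group takes the place of a hydrogen, turning 4-hydroxyphenyl into 3,4-dihydroxyphenyl.

Among the measured compounds shown here, three measured steps bear on this change, since each alters a substituent on an aromatic ring. For the measured compounds named here, the first is a step that the two limits leave unreadable from compound 1 to compound 3. The second is a step that the two limits leave unreadable from compound 2 to compound 3. The third is a step that the two limits leave unreadable from compound 1 to compound 2. None of them has a readable size, so together they give no direction for adding a hydroxy group. The likeliest outcome is therefore that compound 4 also reports only a limit, although a true number cannot be ruled out. The expected change is an at least 1.1-fold lower number from compound 3 to compound 4 (0.04 log units; that floor lies within the scatter), with no firm direction. For compound 4 the estimated value is 18000 nM, with an expected range from 6000 nM to 40000 nM.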

Compound 4, half-maximal inhibitory concentration: > 20000 nM
Compound 4 gave a limit, no number; the forecaster's own chance of this, stated with the estimate: 60%; middle value at least 1.1-fold (0.04 log units) away from the limit.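

In this assay compound 4 gives > 20000 nM, which is a limit and not a number. Its steps from compound 1, compound 2 and compound 3 therefore cannot be read. The compounds shown leave open whether any change on these aromatic rings would give a measured number, since all of them share one limit: the limit of > 20000 nM in this assay, at which 4 of the 4 values shown sit.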